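The source may hold more compounds than are shown below. What is called first, only, known or untested is meant among the compounds shown, and "the series" means these compounds.

Among the compounds with values here, in an ADME assay on MT4 cells (Homo sapiens) for cytotoxicity, read by MTT assay, with a stated time of 96 h (on this read-out lower numbers stand for higher toxicity in this test and higher numbers for lower toxicity in this test), two compounds have numbers so far. Compound 1 (`CCC(=O)Oc1ccc2ccc(=O)oc2c1Cc1c[nH]c2ccccc12`) gives 65000 nM, and compound 2 (`Cc1[nH]c2ccccc2c1Cc1c(OC(=O)CCCC(=O)O)ccc2ccc(=O)oc12`) gives 27000 nM. Compound 2 therefore holds the lower of the two numbers, and its gap to compound 1 lies beyond the usual scatter. Compound 3 (`CCC(=O)Oc1ccc2ccc(=O)oc2c1Cc1c(C)[nH]c2ccccc12`) has not yet been measured. The structural difference from compound 2 to compound 3 is hydrogen in place of carboxymethyl on a saturated chain carbon, two bonds along the chain from a carbonyl carbon. This puts hydrogen in place of carboxymethyl on a saturated chain carbon, two bonds along the chain from a carbonyl carbon. Cut one bond further out, the same difference reads (3-carboxypropyl)carbonyl to propanoyl. Within the data shown here, no measured pair shows this change alone, so its size in this assay cannot be read directly. A small upward step, of about the size of the scatter, is expected. Among the measured compounds shown here, the only guide is compound 1, which also carries propanoyl and gives 65000 nM. The estimated step is a 1.7-fold higher number from compound 2 to compound 3 (0.22 log units; within the scatter). For compound 3 the expected value is 45000 nM, with an estimated range of 18000 nM to 100000 nM.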

Compound 3, half-maximal cytotoxic concentration: 80000 nM
For compound 3 the middle estimate is 1.8-fold (0.25 log units) below the measured one; low and high end bracket the measured number.
By their numbers in this assay, from the lowest: compound 2; then compounds 1 and 3 (each within the scatter of the next).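

Going from (3-carboxypropyl)carbonyl to propanoyl gives a 3.0-fold higher number from compound 2 to compound 3 (0.47 log units; beyond the scatter) in this assay. Within the data shown here, this is the first reading of this change alone, and it shows that the chain on the carbonyl carbon can move the number in this test beyond the scatter. Methyl in place of hydrogen on an aromatic carbon gives a 1.2-fold higher number from compound 1 to compound 3 (0.09 log units; within the scatter), so with propanoyl on both, compound 1 and compound 3 cannot be told apart, and the two changes read quite differently on the shared core. The compounds shown include no measurement that accounts for the step from (3-carboxypropyl)carbonyl to propanoyl, and its cause stays unknown.

The step from compound 2 to compound 3 changes chain length and the carboxylic acid end together, so the two stay unseparated; a plain butanoyl chain, or an amine at the end of the same chain, would be needed to tell them apart. As far as these compounds go, whether the aromatic methyl also stays within the scatter alongside (3-carboxypropyl)carbonyl remains open, as does the reading for an ethyl group in its place.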